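Indole nitrogen substituent swap in a rat whole-animal series

The source may hold more compounds than are shown below. What is called first, only, known or untested is meant among the compounds shown, and "the series" means these compounds.

Two compounds of the shared core have numbers in a functional assay on the whole organism for inhibition, with Rattus norvegicus as the target; a higher number here means that more compound is needed for the effect, a lower number that less compound is needed. Compound 1 `CN(C)C(=O)n1cc(C(=O)c2ccn3c2CSC3c2cccnc2)c2ccc(Sc3ccc(F)cc3)cc21` gives 0.27 mg/kg, and compound 2 `CCNC(=O)n1cc(C(=O)c2ccn3c2CSC3c2cccnc2)c2ccc(-c3ccc(F)cc3)cc21` gives 0.18 mg/kg; compound 2 has the lower of the two numbers, and its gap to compound 1 lies within the scatter. Compound 3 `O=C(O)CCn1cc(C(=O)c2ccn3c2CSC3c2cccnc2)c2ccc(-c3ccc(F)cc3)cc21` is not yet measured. It differs from compound 2 by 2-carboxyethyl in place of ethylcarbamoyl on an aromatic nitrogen. Going by the values given here, no measured pair covers a change of this kind, so the expected step of a 2.2-fold higher number from compound 2 to compound 3 (0.35 log units; beyond the scatter) rests on compound 2 alone and is set as a small rise, close to the edge of the scatter. For compound 3 in this assay the estimate is 0.4 mg/kg, within 0.12 mg/kg to 1.5 mg/kg.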

Compound 3, dose for half-maximal effect: 0.1 mg/kg
Estimate against measurement, compound 3: 4.0-fold (0.60 log units) above; the measured number lies below the stated range.
By their numbers in this assay, from the lowest: compounds 3, 2 and 1 (each within the scatter of the next, the first and the last beyond it).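

In this assay the change from ethylcarbamoyl to 2-carboxyethyl on the aromatic nitrogen gives a 1.8-fold lower number from compound 2 to compound 3 (0.26 log units; within the scatter) and so does not separate the two groups. This position therefore holds a carboxylic acid chain as well as a carbamoyl group, and the ethylcarbamoyl group is not needed for a number at the level of compound 2. Nothing available explains this result.

Still open, on these data alone, is whether the methyl ester of the 2-carboxyethyl group reads the same. As far as these compounds go, a longer chain ending in a carboxylic acid, or a chain ending in an amine, is equally open.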